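The source may hold more compounds than are shown below. What is called first, only, known or untested is meant among the compounds shown, and "the series" means these compounds.

The compounds here share one core, and three of them have been tested in a functional assay on HepG2 cells (Homo sapiens) for cytotoxicity, read by MTT assay, with a stated time of 48 h; a higher number here means a weaker inhibitor, a lower number a stronger inhibitor. Compound 1 `COc1cc(-c2nnc3n2NC(c2ccco2)C(C(=O)c2ccccc2F)S3)cc(OC)c1OC` gives in this assay only a limit, > 100000 nM. Compound 3 `COc1cc(-c2nnc3n2NC(c2ccco2)C(C(=O)C2CC2)S3)cc(OC)c1OC` likewise gives only a limit, > 100000 nM. Going by the values given here, compound 2 `COc1cc(-c2nnc3n2NC(c2ccco2)C(C(=O)c2ccc(Cl)cc2)S3)cc(OC)c1OC` is the single compound with a number, 78600 nM, so it is the only fixed point among the three. The other two sit at the edge of what the assay reports (the limit of > 100000 nM in this assay, at which 2 of the 3 values shown sit). Every measured step changes the group on the carbonyl carbon: an at least 1.2-fold lower number from compound 1 to compound 2 (0.10 log units; that floor lies within the scatter), a step that the two limits leave unreadable from compound 1 to compound 3 and an at least 1.2-fold higher number from compound 2 to compound 3 (0.10 log units; that floor lies within the scatter), and each is either unreadable or within the scatter. Compound 4 `COc1cc(-c2nnc3n2NC(c2cccs2)C(C(=O)c2ccc(Cl)cc2)S3)cc(OC)c1OC` differs from compound 2 at another place: thiophen-2-yl in place of furan-2-yl on a saturated ring carbon. No measured step touches that position, so nothing shown here points to a shift in either direction, and the expected step of a 1.1-fold higher number from compound 2 to compound 4 (0.03 log units; within the scatter) is none beyond the scatter. Compound 4 is therefore estimated at 85000 nM, with a range from 40000 nM to 200000 nM.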

Compound 4, half-maximal inhibitory concentration: 13200 nM
Estimate against measurement, compound 4: 6.4-fold (0.81 log units) above; the whole stated range lies above it.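

In this assay, thiophen-2-yl in place of furan-2-yl on the saturated ring carbon gives a 6.0-fold lower number from compound 2 to compound 4 (0.77 log units; beyond the scatter) and is the first step among these compounds that lies beyond the scatter. Going by these compounds alone, this shows that the position, which no earlier step touched, can move the result even when the incoming and outgoing rings match in heavy-atom count and differ in a single ring atom, sulfur for oxygen. Nothing shown here gives a measured reason for this shift.

On these data alone, what a pyridine ring or an amine would do on the saturated ring carbon stays open, as does whether the shift holds with anything other than the (4-chlorophenyl)carbonyl group. The groups on the carbonyl carbon also remain hard to rank because so many values are limits: the limit of > 100000 nM in this assay, at which 2 of the 4 values shown sit.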